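From methoxy to methylamino on a shared core

The source may report more compounds than this note shows. Statements on the series, on what has been measured and on what is new or still open speak of the compounds shown alone.

In a functional assay on CEM-DNR-bulk cells (Homo sapiens), read by MTT assay, with a stated time of 72 h (on this read-out higher numbers stand for weaker inhibition and lower numbers for stronger inhibition), compound 1 `C#Cc1cn([C@@H]2O[C@H](CO)[C@@H](O)[C@H]2O)c2ncnc(OC)c12` gives 3490 nM, the higher of the two numbers measured. Compound 2 `C#Cc1cn([C@@H]2O[C@H](CO)[C@@H](O)[C@H]2O)c2ncnc(SC)c12` gives 110 nM. For compound 3 `CNc1ncnc2c1c(-c1cc3ccccc3o1)cn2[C@@H]1O[C@H](CO)[C@@H](O)[C@H]1O` there is only a limit, > 20000 nM. Compound 3 also carries methylamino, but it differs from compound 4 elsewhere as well, so it offers little guidance here. Compound 4 `C#Cc1cn([C@@H]2O[C@H](CO)[C@@H](O)[C@H]2O)c2ncnc(NC)c12` follows from compound 1 by one change, (methylamino in place of methoxy on an aromatic carbon), with methylamino in place of methoxy on an aromatic carbon. Among the measured compounds shown here, the only measured step at that carbon is a 32-fold lower number from compound 1 to compound 2 (1.50 log units; beyond the scatter), which was large but brought in a different group. A smaller move in the same direction is expected, and the estimated step is a 3.5-fold lower number from compound 1 to compound 4 (0.54 log units; beyond the scatter). For compound 4 the estimated value is 1000 nM, with an expected range from 120 nM to 8000 nM.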

Compound 4, half-maximal inhibitory concentration: 18500 nM
Compound 4: middle estimate off by 19-fold (1.27 log units), on the low side; measured number outside the range, above it.
By their numbers in this assay, from the lowest: compound 2; then compound 1; then compound 4. At a limit, above all of these: compound 3.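

In this assay, the change at this carbon proves to depend on the entering group: methylamino, which adds a hydrogen-bond donor to what methoxy offers, gives a 5.3-fold higher number from compound 1 to compound 4 (0.72 log units; beyond the scatter), the opposite direction to a 32-fold lower number from compound 1 to compound 2 (1.50 log units; beyond the scatter). The two entering groups lie far apart, with a 170-fold higher number from compound 2 to compound 4 (2.23 log units; beyond the scatter). Compound 3 has only a limit: the limit of > 20000 nM in this assay, at which 1 of the 4 values shown sits.

The remaining step is only a floor, an at least 1.0-fold lower number from compound 3 to compound 4 (0.03 log units; that floor lies within the scatter), so it cannot be read as a measured difference.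

The compounds shown leave open whether dimethylamino or ethylsulfanyl at this carbon would track methylamino or methylsulfanyl. They also leave open whether the hydrogen on the methylamino nitrogen matters.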